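Thiophene-bearing dihydropyrimidinones at the adenosine A3 receptor

A few compounds are considered here, and "the series" means these few. Any claim that something is new, unique, unknown or untested is made for them only; others in the source may bear on it.

Compound 1, `CCCOC(=O)C1=C(C)NC(=O)NC1c1cccs1`, 32%; compound 2, `CC1=C(C(=O)OCC(C)C)C(c2cccs2)NC(=O)N1`, 11%; compound 3, `CC1=C(C(=O)NC(C)C)C(c2cccs2)NC(=O)N1`, 1%.

In an assay on membranes from HeLa cells for displacement of a labelled ligand from adenosine receptor A3 (Homo sapiens), read by scintillation counting, with a stated time of 180 min, tested at 1 uM (a higher number here means more inhibition at the concentration tested (going by the name of the read-out), a lower number less inhibition), compound 3 stands lowest of the three numbers. Its nearest neighbour is compound 2, whose value lies within the scatter of compound 3, so no order between the two can be claimed; its furthest neighbour is compound 1, a gap that is beyond the scatter. Compound 4, `CCSC(=O)C1=C(C)NC(=O)NC1c1cccs1`, has not yet been measured. It differs from compound 3 as follows: ethylsulfanyl in place of isopropylamino on a carbonyl carbon. Going by the values given here, two measured steps bear on this change, both replacing an alkoxy group with isopropylamino on the same carbonyl carbon: a number 31 percentage points lower from compound 1 to compound 3 (beyond the scatter) and a number 10 percentage points lower from compound 2 to compound 3 (within the scatter). Both ran downward, one beyond the scatter, one within it, so the isopropylamino group is associated with the lower numbers here. Compound 4 removes that group again and puts a different non-nitrogen substituent in its place, so a modest upward step is expected, a number 17 percentage points higher from compound 3 to compound 4 (beyond the scatter), though not necessarily a full return to the level of compound 1. Compound 4 is therefore estimated at 18%, within a range of 4% to 38%.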

Compound 4, a percentage reported as inhibition, at one concentration (the size of the read-out at that concentration, not a potency): 1%
For compound 4 the middle estimate is 17 percentage points above the measured one; measured number below the stated range.
By their numbers in this assay, from the lowest: compounds 3, 4 and 2 (each within the scatter of the next); then compound 1.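

In this assay, the first new step (no change at the digits printed from compound 3 to compound 4 (within the scatter)) shows that replacing isopropylamino does not by itself restore the number: ethylsulfanyl, with no hydrogen-bond donor, cannot be told apart from isopropylamino, which has one. Going by these compounds alone, the second step (a number 10 percentage points lower from compound 2 to compound 4 (within the scatter)) likewise leaves ethylsulfanyl unresolved from isobutoxy, while the third (a number 31 percentage points lower from compound 1 to compound 4 (beyond the scatter)) leaves propoxy as the only group at this carbonyl carbon whose compound stands clear of the other three, so the nitrogen of isopropylamino is not needed for the low readings. Nothing measured here explains why these groups separate in this way.

Open, going by these compounds, is whether ethoxy or a longer chain such as butoxy would match propoxy on this carbonyl carbon. On these data alone, it is also open whether propylsulfanyl would read like propoxy or like ethylsulfanyl, which would show whether the sulfur or the chain matters more.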